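Two Halogen Patterns on the Aromatic Ring of a Shared Core

The source may hold more compounds than are shown below. What is called first, only, known or untested is meant among the compounds shown, and "the series" means these compounds.

Compound 1: `CCCc1cc(N)c2cc(NC(=O)/C=C/c3ccc(C(C)(C)C)cc3)ccc2n1` — a functional assay on HEK293 cells for activation of melanin-concentrating hormone receptor 1 (Homo sapiens), read by inositol phosphate accumulation; a lower number here means that less compound is needed, a higher number that more compound is needed for the effect: 910 nM
Compound 2: `CCCc1cc(N)c2cc(NC(=O)/C=C/c3ccc(Br)cc3)ccc2n1` — this assay: 93 nM

Within the data shown here, compound 2 gives the lowest of the two numbers measured in this assay; the only other compound, compound 1, sits above it, and the single measured step, a 9.8-fold lower number from compound 1 to compound 2 (0.99 log units; beyond the scatter), describes that gap. Compound 3, `CCCc1cc(N)c2cc(NC(=O)/C=C/c3ccc(Cl)c(Cl)c3)ccc2n1`, differs from compound 2 by 3,4-dichlorophenyl in place of 4-bromophenyl on a double-bonded chain carbon bound to a double-bonded chain carbon. Among the measured compounds shown here, the measured step bears on this change only loosely: it shows that a halogen-bearing ring in that position gave a lower number than a tert-butyl-bearing one, but no measured pair compares one halogen pattern with another. With nothing more to go on, the expectation for compound 3 is a change that stays within the scatter or is at most small, a 1.1-fold higher number from compound 2 to compound 3 (0.03 log units; within the scatter). Compound 3 is therefore estimated at 100 nM in this assay, with a range from 30 nM to 330 nM.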

Compound 3, half-maximal effective concentration: 990 nM
For compound 3 the middle estimate is 9.9-fold (1.00 log units) below the measured one, and the stated range ends below it.
By their numbers in this assay, from the lowest: compound 2; then compounds 1 and 3 (each within the scatter of the next).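

In this assay, replacing 4-bromophenyl with 3,4-dichlorophenyl gives an 11-fold higher number from compound 2 to compound 3 (1.03 log units; beyond the scatter), so carrying halogen on this ring does not by itself secure the low number of compound 2; the halogen pattern matters at this place. Compound 1, with its tert-butyl group, and compound 3, with its two chlorines, now lie within the scatter of each other, leaving compound 2 alone at the low end of the three. Nothing available explains why these two halogen patterns read so differently.

The loss of bromine and the arrival of the two chlorines come together in this one change, and a 4-chlorophenyl group at this place would begin to pull them apart. Going by these compounds, how a ring carrying a methoxy group or a carboxylic acid would read in this assay also stays open.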